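This account rests on a few compounds, and the source may have more. Where it says the series, first, only, none or still open, it means among the compounds named here.

In a functional assay on A2780 cells (Homo sapiens) for antiproliferative activity, read by CellTiter-Glo, with a stated time of 4 days (a higher number here means a weaker inhibitor, a lower number a stronger inhibitor), compound 1 `CC(=O)NCc1ncc2cc(COc3ccc(C(=O)NCc4cccnc4)cc3)n(CCC3CCCCC3)c2n1` gives 15 nM and compound 2 `Nc1ccc(CNC(=O)Nc2ccc(CN3C(=O)c4ccccc4C3=O)cc2)cn1` gives 7 nM and so holds the lower of the two numbers, with a gap beyond the usual scatter. Compound 3 `O=C(NCc1cccnc1)Nc1ccc(CN2C(=O)c3ccccc3C2=O)cc1` differs from compound 2 through hydrogen in place of amino on an aromatic carbon and so has pyridin-3-yl where compound 2 has 6-aminopyridin-3-yl. Among the compounds with values here, no measured pair shows this change. In this assay the expected step of a 1.2-fold lower number from compound 2 to compound 3 (0.07 log units; within the scatter) is estimated to stay within the scatter, with no direction foreseen. For compound 3 the estimate is 6 nM with an expected range from 2 nM to 20 nM overall.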

Compound 3, half-maximal inhibitory concentration: 100 nM
Beside the measured number, compound 3's estimate is 17-fold (1.22 log units) below it; measured number outside the range, above it.
By their numbers in this assay, from the lowest: compound 2; then compound 1; then compound 3.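

In this assay, replacing amino with hydrogen on this aromatic carbon, next to the ring nitrogen, brings a 14-fold higher number from compound 2 to compound 3 (1.15 log units; beyond the scatter), a large step. The earlier compounds shown here gave no view of this position, and this single pair shows that the number depends strongly on what sits there. Nothing at hand explains the size of this step.

The compounds shown leave open whether a methylamino, dimethylamino, hydroxyl or methyl group on this carbon would keep the number near that of compound 2. They also leave open whether moving the amino group elsewhere on the ring would do so.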